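Swapping a para fluoro for bromo on the benzyl group

The source may report more compounds than this note shows. Statements on the series, on what has been measured and on what is new or still open speak of the compounds shown alone.

Measured so far:
- compound 1 `CC(C)(C)c1cc(/C=C/C(=O)NCCC2CCN(Cc3ccccc3F)CC2)cc(C(C)(C)C)c1O`: 60200 nM
- compound 2 `CC(C)(C)c1cc(/C=C/C(=O)NCCC2CCN(Cc3ccc(F)cc3)CC2)cc(C(C)(C)C)c1O`: 59600 nM

Both compounds were tested in an assay on isolated protein for inhibition of Amine oxidase [flavin-containing] A (Homo sapiens), read by fluorescence, with stated times of 15 min and 20 min; on this read-out higher numbers stand for weaker inhibition and lower numbers for stronger inhibition. Compound 1 gives 60200 nM, and compound 2 gives 59600 nM. Compound 2 carries the lowest of the two numbers, but the step of a 1.0-fold lower number from compound 1 to compound 2 (0.00 log units; within the scatter) is within the scatter, so the two compounds cannot be told apart; moving the fluoro from one place on the ring to another made no visible difference.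

Compound 3 `CC(C)(C)c1cc(/C=C/C(=O)NCCC2CCN(Cc3ccc(Br)cc3)CC2)cc(C(C)(C)C)c1O` has not yet been measured. It differs from compound 2 by bromo in place of fluoro on an aromatic carbon. For the measured compounds named here, no measured pair shows a change of halogen on this ring, so the one recorded step is only a loose guide: it tells that the benzyl ring tolerated a change without any shift in the number. On that basis the expected step of a 1.2-fold lower number from compound 2 to compound 3 (0.08 log units; within the scatter) is small, with no clear direction beyond the scatter. Compound 3 is therefore estimated at 50000 nM, within a range from 20000 nM to 150000 nM.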

Compound 3, half-maximal inhibitory concentration: 73200 nM
Estimate against measurement, compound 3: 1.5-fold (0.17 log units) below; the range from low to high includes it.
By their numbers in this assay, from the lowest: compounds 2, 1 and 3 (each within the scatter of the next).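

Bromo in place of fluoro at this place, on an aromatic carbon para to a large group, gives a 1.2-fold higher number from compound 2 to compound 3 (0.09 log units; within the scatter) in this assay, so this first change of halogen on the ring leaves the two compounds indistinguishable. Changing both the halogen and its place on the ring also gives a 1.2-fold higher number from compound 1 to compound 3 (0.08 log units; within the scatter) and therefore no readable difference, which extends the earlier finding about moving the fluoro: all three halogen-bearing benzyl compounds lie within the scatter of one another, and the data so far give no ranking among them. Nothing available bears on why these numbers cannot be told apart.

On these data alone, whether this benzyl ring responds to anything other than a halogen remains open, for example an amine, a carboxylic acid or a methoxy group at the same place, or a ring with no substituent at all. As far as these compounds go, it is also open whether a longer chain between the amide and the saturated ring, rather than a change on the benzyl ring, would shift the number beyond the scatter.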